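A few compounds are considered here, and "the series" means these few. Any claim that something is new, unique, unknown or untested is made for them only; others in the source may bear on it.

Measured in an ADME assay on microsomes from liver (Mus musculus) for metabolic stability, read by LC-MS, with NADPH named in the record, with a stated time of 60 min, tested at 1 uM, in the absence of a further agent (a lower number here means that less of the compound is left, a higher number that more of the compound is left), with each value a limit of the assay:

Compound 1 `CCCCCC(=O)N[C@@H]1CCN(c2cc(C)nn3c(-c4ccc(OC)c(OC)c4)c(C)nc23)C1`: > 95%
Compound 2 `COc1ccc(-c2c(C)nc3c(N4CC[C@@H](NC(=O)OCc5ccccc5)C4)cc(C)nn23)cc1OC`: > 95%
Compound 3 `COc1ccc(-c2c(C)nc3c(N4CC[C@@H](NC(=O)OC5CCCCC5)C4)cc(C)nn23)cc1OC`: > 95%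

Compound 3 stands at > 95%, which is a limit of the assay and not a number. It therefore sits with the other two compounds at the limit of > 95% in this assay, at which 3 of the 3 values shown sit.

Compound 4 `COc1ccc(-c2c(C)nc3c(N4CC[C@@H](NS(=O)(=O)C(C)C)C4)cc(C)nn23)cc1OC` carries isopropylsulfonyl in place of cyclohexyloxycarbonyl on an amine nitrogen. Among the measured compounds shown here, its change replaces the whole group on that nitrogen, and none of the measured compounds carries isopropylsulfonyl.

For the measured compounds named here, three measured steps bear on it, all among groups on a carbonyl carbon or its oxygen. They are a step that the two limits leave unreadable from compound 1 to compound 2, a step that the two limits leave unreadable from compound 1 to compound 3 and a step that the two limits leave unreadable from compound 2 to compound 3. None of them has a readable size, so they give no measure for the new change. Going by the values given here, they show only that these three different groups leave the reading at the same limit.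

On that basis, no step beyond the scatter is expected in either direction, and the expected step is a number no higher from compound 3 to compound 4 (the limit leaves the size open). The wider lower side of the range allows for the untested group.

For compound 4 the estimated value is 95%, with an expected range from 80% to 100%.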

Compound 4, percent of the compound remaining: > 95%
Compound 4 gave a limit, no number; the forecaster's own chance of this, stated with the estimate: 55%; the middle value lies on the limit itself.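

In this assay compound 4 gives > 95%, which is a limit of the assay and not a number. The steps to compound 4 from compound 1, compound 2 and compound 3 therefore cannot be read. The compounds shown leave open how these four rank among themselves and which group on the amine nitrogen, if any, would leave less compound remaining.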